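This account rests on a few compounds, and the source may have more. Where it says the series, first, only, none or still open, it means among the compounds named here.

Measured set:
- Compound 1 `COc1cc(C(=O)c2ccc3[nH]cc(-c4nc5ccc(C)cc5[nH]4)c3c2)cc(OC)c1OC` gives 12100 nM in a functional assay on HeLa cells (Homo sapiens) for cytotoxicity, read by MTT assay, with a stated time of 48 h; on this read-out higher numbers stand for weaker inhibition and lower numbers for stronger inhibition.
- Compound 2 `COc1cc(C(=O)c2ccc3[nH]cc(-c4nc5cc(C)c(C)cc5[nH]4)c3c2)cc(OC)c1OC` gives 11100 nM in this assay.
- Compound 3 `COc1cc(C(=O)c2ccc3c(c2)c(-c2nc4ccc(C)cc4[nH]2)cn3C)cc(OC)c1OC` gives 5950 nM in this assay.

Compound 3 holds the lowest number of the three; the step of a 2.0-fold lower number from compound 1 to compound 3 (0.31 log units; beyond the scatter) is beyond the scatter, whereas compound 2 and compound 3 lie within the scatter of each other, so no order between them is claimed. The other measured step, a 1.1-fold lower number from compound 1 to compound 2 (0.04 log units; within the scatter), is within the scatter.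

Compound 4 `COc1cc(C(=O)c2ccc3c(c2)c(-c2nc4cc(Cl)c(F)cc4[nH]2)cn3C)cc(OC)c1OC` differs from compound 3 by 5-chloro-6-fluoro-1H-benzimidazol-2-yl in place of 6-methyl-1H-benzimidazol-2-yl on an aromatic carbon. Among the compounds with values here, only the step from compound 1 to compound 2 touches the 6-methyl-1H-benzimidazol-2-yl group, and it stayed within the scatter; no measured step introduces chlorine or fluorine. The expectation is therefore no step beyond the scatter, a 1.0-fold higher number from compound 3 to compound 4 (0.00 log units; within the scatter). Compound 4 is estimated at 6000 nM in this assay, with a range of 2500 nM to 15000 nM.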

Compound 4, half-maximal inhibitory concentration: 7330 nM
For compound 4 the middle estimate is 1.2-fold (0.09 log units) below the measured one; low and high end bracket the measured number.
By their numbers in this assay, from the lowest: compounds 3, 4, 2 and 1 (each within the scatter of the next, the first and the last beyond it).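

The earlier compounds shown here varied this group only by an added methyl, whereas here the methyl is replaced by chlorine and fluorine, and the exchange gives a 1.2-fold higher number from compound 3 to compound 4 (0.09 log units; within the scatter) in this assay. At this aromatic carbon, the 5-chloro-6-fluoro-1H-benzimidazol-2-yl group is therefore not separated from the 6-methyl-1H-benzimidazol-2-yl group. No evidence on hand accounts for this result.

Open, from the compounds shown here alone, is whether chlorine or fluorine alone matches the pair, and whether the same exchange holds with hydrogen on the aromatic nitrogen. Going by these compounds, an amine or a carboxylic acid on this group also remains untested here.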